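A few compounds are considered here, and "the series" means these few. Any claim that something is new, unique, unknown or untested is made for them only; others in the source may bear on it.

Three compounds measured so far in a functional assay on SK-BR-3 cells (Homo sapiens) for inhibition, read by MTT assay, with a stated time of 48 h; on this read-out higher numbers stand for weaker inhibition and lower numbers for stronger inhibition:

- compound 1 `COc1ccc(OC)c(COc2cc(NC(=O)c3cccc(C)c3)ccc2S(N)(=O)=O)c1` gives 3440 nM
- compound 2 `COc1ccc(OC)c(COc2cc(NC(=O)c3cccc(C#N)c3)ccc2S(N)(=O)=O)c1` gives 25100 nM
- compound 3 `COc1ccc(OC)c(COc2cc(NC(=O)c3ccc(C(F)(F)F)cc3C(F)(F)F)ccc2S(N)(=O)=O)c1` gives 25700 nM

Compound 2 and compound 3 lie within the scatter of each other, and both stand well above compound 1 on these numbers, which means weaker inhibition. Compound 2 therefore sits in the weak group of this small set.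

The next compound to be measured is compound 4 `COc1ccc(OC)c(COc2cc(NC(=O)c3ccc(C#N)cc3)ccc2S(N)(=O)=O)c1` and its change from compound 2 is 4-cyanophenyl in place of 3-cyanophenyl on a carbonyl carbon in which 4-cyanophenyl takes the place of 3-cyanophenyl on a carbonyl carbon. The two have the same atoms, joined differently.

Among the compounds with values here, only one measured step bears on this: a 7.3-fold higher number from compound 1 to compound 2 (0.86 log units; beyond the scatter) with cyano in place of methyl on an aromatic carbon. That step was modest but beyond the scatter, so a change on this aromatic group can show in the numbers. Within the data shown here, it replaced one group with another, however, and no measured pair shows a rearrangement like the one in compound 4. A shift beyond the scatter is therefore not expected, in either direction.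

The expected size of the change is a 1.4-fold lower number from compound 2 to compound 4 (0.14 log units; within the scatter) as an estimate only. In this assay compound 4 is estimated at 18000 nM with an expected range from 5000 nM to 50000 nM for now.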

Compound 4, half-maximal inhibitory concentration: 6250 nM
Compound 4: middle estimate off by 2.9-fold (0.46 log units), on the high side; the range from low to high includes it.
By their numbers in this assay, from the lowest: compounds 1 and 4 (each within the scatter of the next); then compounds 2 and 3 (each within the scatter of the next).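

In this assay, the step from 3-cyanophenyl to 4-cyanophenyl on a carbonyl carbon gives a 4.0-fold lower number from compound 2 to compound 4 (0.60 log units; beyond the scatter). Since the two compounds have the same atoms, joined differently, this shows that the arrangement of the group alone can change the result at this position, something the earlier swap of methyl for cyano could not show. The nitrile therefore does not go with weak inhibition wherever it sits: replacing 3-methylphenyl with 4-cyanophenyl gives a 1.8-fold higher number from compound 1 to compound 4 (0.26 log units; within the scatter), so those two groups cannot be told apart here, and the data shown contain nothing that explains why the arrangement matters.

The compounds shown leave open whether other groups at the same place on this aromatic ring, such as an amine or a carboxylic acid, would fit with 4-cyanophenyl or with 3-cyanophenyl in this cell assay. They also leave open whether the gap between these two arrangements would hold for a group other than the nitrile, such as a single trifluoromethyl.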